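Removing the chloro group from compound 1

The compounds below may be only part of what the source reports. "The series", "measured", "known", "first", "only" and "open" are said of these compounds alone.

Measured compounds:
compound 1, `Clc1ccc(NC2=NCCC3(CCCCC3)S2)cc1`, 2.5
compound 2, `CC(=O)c1cccc(NC2=NCCC3(CCCCC3)S2)c1`, 2.37
compound 3, `CC(=O)c1ccc(NC2=NCCC3(CCCCC3)S2)cc1`, 1.97

All three share one core and differ only in the group on the outer benzene ring. In a physicochemical assay for lipophilicity, measured as octanol-water partition, at pH 7.4 (a lower number here means a more polar compound, a higher number a more lipophilic compound), compound 1 stands highest of the three numbers. Its nearest neighbour is compound 2, and that gap lies within the scatter, so the two cannot be ordered. Its furthest neighbour is compound 3, reached by a number 0.53 log units lower from compound 1 to compound 3 (beyond the scatter), a modest step beyond the scatter.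

Compound 4, `c1ccc(NC2=NCCC3(CCCCC3)S2)cc1`, has not yet been measured in this assay. It differs from compound 1 in one place: hydrogen in place of chloro on an aromatic carbon. No measured step covers this exact change; the only step shown, a number 0.53 log units lower from compound 1 to compound 3 (beyond the scatter), swaps chloro for acetyl rather than for hydrogen, so it bears on the question only loosely, through the loss of chloro. With one chlorine leaving and nothing heavier than hydrogen entering, compound 4 is expected to give a lower number than compound 1 in this assay, a step of about a number 0.70 log units lower from compound 1 to compound 4 (beyond the scatter). The estimate for compound 4 is 1.8, expected between 1.4 and 2.2.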

Compound 4, distribution coefficient: 1.02
Estimate against measurement, compound 4: 0.78 log units above, and the stated range ends above it.
By their numbers in this assay, from the lowest: compound 4; then compound 3; then compounds 2 and 1 (each within the scatter of the next).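

In this assay, hydrogen in place of chloro gives a number 1.48 log units lower from compound 1 to compound 4 (beyond the scatter), much larger than a number 0.53 log units lower from compound 1 to compound 3 (beyond the scatter) seen when acetyl replaces chloro, so the earlier swap had hidden how much this position can move the number. Acetyl also gives a higher number than hydrogen: replacing it gives a number 0.95 log units lower from compound 3 to compound 4 (beyond the scatter) and, for the acetyl of compound 2, a number 1.35 log units lower from compound 2 to compound 4 (beyond the scatter), so each of the three groups stands clearly above the unsubstituted ring of compound 4. Nothing available explains the size of these steps.

Going by these compounds, how a fluoro group, a methoxy group, an amine or a carboxylic acid would compare on this ring remains open. So does whether hydrogen would give the lowest number among a wider set of groups.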